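The source may report more compounds than this note shows. Statements on the series, on what has been measured and on what is new or still open speak of the compounds shown alone.

Compound 1 `Oc1ccc(-c2cc(-c3cccc(O)c3)nc(-c3cccc(O)c3)c2)cc1`: 3810 nM
Compound 2 `Oc1cccc(-c2cc(-c3cccc(O)c3)nc(-c3ccccc3O)c2)c1`: > 50000 nM
Compound 3 `Oc1ccc(-c2cc(-c3ccc(O)cc3)nc(-c3cccc(O)c3)c2)cc1`: 3520 nM

Of the compounds shown here, three built on one shared core have been tested in a functional assay on HCT-15 cells (Homo sapiens) for cytotoxicity, read by CCK-8 assay, with a stated time of 4 days; a higher number here means a weaker inhibitor, a lower number a stronger inhibitor. Compound 3 stands at the lowest of the two numbers obtained, and its nearest neighbour is compound 1, separated by a 1.1-fold lower number from compound 1 to compound 3 (0.03 log units; within the scatter). For the measured compounds named here, compound 2, the one member of the set carrying a 2-hydroxyphenyl group, gives only a limit of the assay, > 50000 nM.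

Compound 4 `Oc1ccc(-c2cc(-c3cccc(O)c3)nc(-c3ccccc3O)c2)cc1` has not yet been measured. It differs from compound 3 in one place: 2-hydroxyphenyl in place of 4-hydroxyphenyl on an aromatic carbon. Going by the values given here, the only measured step, from compound 1 to compound 3, exchanged a 3-hydroxyphenyl for a 4-hydroxyphenyl and stayed within the scatter, so it says little about the present change. Among the compounds with values here, no measured step introduces a 2-hydroxyphenyl; the sole compound that bears one, compound 2, sits at the limit of > 50000 nM in this assay, at which 1 of the 3 values shown sits. Compound 4 is therefore expected to give a clearly higher number in this assay, an estimated step of an 8.5-fold higher number from compound 3 to compound 4 (0.93 log units; beyond the scatter). The estimate for compound 4 is 30000 nM, in a range from 8000 nM to 100000 nM, with a substantial chance that the assay reports only a limit.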

Compound 4, half-maximal inhibitory concentration: 5830 nM
Estimate against measurement, compound 4: 5.1-fold (0.71 log units) above, and the stated range ends above it.
By their numbers in this assay, from the lowest: compounds 3, 1 and 4 (each within the scatter of the next). At a limit, above all of these: compound 2.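

Placed next to the ring nitrogen, the 2-hydroxyphenyl group is compatible with activity in this assay, which the earlier compounds did not show: there is a 1.7-fold higher number from compound 3 to compound 4 (0.22 log units; within the scatter), and there is a 1.5-fold higher number from compound 1 to compound 4 (0.18 log units; within the scatter). Compound 2 carries the same group and gives only a limit of the assay, > 50000 nM. The 2-hydroxyphenyl group alone therefore does not account for that limit, since exchanging 3-hydroxyphenyl for 4-hydroxyphenyl gives an at least 8.5-fold lower number from compound 2 to compound 4 (0.93 log units; beyond the scatter), and the outcome of this exchange depends on the core it is made on: the same change on two cores in this assay, a 1.1-fold lower number (0.03 log units; within the scatter) from compound 1 to compound 3 and an at least 8.5-fold lower number (0.93 log units; beyond the scatter) from compound 2 to compound 4, at least 7.9-fold (0.89 log units) apart, beyond the scatter of two such steps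

The compounds shown carry only hydroxyphenyl groups, so it remains open whether the hydroxyl itself matters at the place next to the ring nitrogen, or whether a methoxy group or an amine on that phenyl ring, or a plain phenyl, would read the same in this assay. Also open, going by these compounds, is how far the dependence on the core extends, as it rests on a single pair of steps, one of which ends at a limit.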